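This account rests on a few compounds, and the source may have more. Where it says the series, first, only, none or still open, it means among the compounds named here.

Going by the values given here, in a functional assay on KM12 cells (Homo sapiens) for antiproliferative activity (a higher number here means a weaker inhibitor of growth, a lower number a stronger inhibitor of growth), compound 3 (`COc1ccc(-c2nc3cc(F)ccc3s2)cc1Cl`) gives 7050 nM, the lowest of the three numbers so far. Compound 2 (`COc1ccc(-c2nc3cc(F)ccc3s2)cc1F`) gives 20600 nM, and compound 1 (`COc1ccc(-c2nc3ccccc3s2)cc1OC`) gives 74200 nM. Compound 4 (`COc1ccc(-c2nc3cc(F)ccc3s2)cc1OC`) has methoxy in place of chloro on an aromatic carbon, ortho to a methoxy group and meta to a large group: methoxy in place of chloro on an aromatic carbon.

Among the compounds with values here, only one measured step touches this place: a 2.9-fold lower number from compound 2 to compound 3 (0.47 log units; beyond the scatter), a modest change with chloro in place of fluoro. Within the data shown here, no measured step shows what methoxy does there. Compound 1 also has methoxy at this place but lacks the fluoro of compound 4, so compound 1 at 74200 nM gives only a weak hint of a higher number. In this assay a step beyond the scatter is therefore not firmly expected in either direction, and the uncertainty is wide. The expected step is a 1.4-fold lower number from compound 3 to compound 4 (0.15 log units; within the scatter). For compound 4 the estimated value is 5000 nM, with an expected range from 100 nM to 30000 nM.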

Compound 4, concentration for 50% growth inhibition: 290 nM
For compound 4 the middle estimate is 17-fold (1.24 log units) above the measured one; the range from low to high includes it.
By their numbers in this assay, from the lowest: compound 4; then compound 3; then compound 2; then compound 1.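

In this assay, methoxy at this place, on an aromatic carbon ortho to a methoxy group, gives far lower numbers than either halogen: methoxy in place of chloro gives (a 24-fold lower number from compound 3 to compound 4 (1.39 log units; beyond the scatter)) and methoxy in place of fluoro gives (a 71-fold lower number from compound 2 to compound 4 (1.85 log units; beyond the scatter)), both much larger than the modest step between the halogens (a 2.9-fold lower number from compound 2 to compound 3 (0.47 log units; beyond the scatter)). The fluoro on the shared core also proves to matter a great deal with methoxy at this place (a 260-fold lower number from compound 1 to compound 4 (2.41 log units; beyond the scatter)), so the high number without fluoro said little about methoxy itself. No evidence available here accounts for these steps.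

The compounds shown leave open whether a hydroxy, an ethoxy or an amine at this place would give a number as low. They also leave open whether fluoro on the core has so large a step when chloro stands at this place.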